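Swapping trifluoromethyl for chloro on a urea aryl ring

The source may hold more compounds than are shown below. What is called first, only, known or untested is meant among the compounds shown, and "the series" means these compounds.

Three members of this series have been measured. Compound 1 `O=C(Nc1cccc(-n2cc(-c3ccncc3)c(-c3cc(O)cc(Cl)c3)n2)c1)Nc1ccc(Cl)c(C(F)(F)F)c1` gives -24.9% in a functional assay on Malme-3M cells (Homo sapiens) for inhibition, read by sulforhodamine B assay, with a stated time of 48 h, tested at 10 uM; a higher number here means a weaker effect of the compound at the concentration tested, a lower number a stronger effect. Compound 2 `O=C(Nc1cccc(-n2cc(-c3ccncc3)c(-c3cc(O)cc(Cl)c3)n2)c1)Nc1ccc(Cl)c(Cl)c1` carries the change chloro in place of trifluoromethyl on an aromatic carbon and gives -35.1%, the step being a number 10.2 percentage points lower from compound 1 to compound 2 (beyond the scatter). Compound 3 `COc1cc(Cl)cc(-c2nn(-c3cccc(NC(=O)Nc4ccc(Cl)c(C(F)(F)F)c4)c3)cc2-c2ccncc2)c1` differs from compound 1 by methyl in place of hydrogen on an oxygen on an aromatic ring; compound 3 gives -19.8%, a step of a number 5.1 percentage points higher from compound 1 to compound 3 (within the scatter). Compound 4 `COc1cc(Cl)cc(-c2nn(-c3cccc(NC(=O)Nc4ccc(Cl)c(Cl)c4)c3)cc2-c2ccncc2)c1` is not yet measured; it differs from compound 3 by chloro in place of trifluoromethyl on an aromatic carbon, the same change that was made from compound 1 to compound 2, at an identically described place. For compound 4 the expected step is a number 10.2 percentage points lower from compound 3 to compound 4 (beyond the scatter), which rests on compound 1 and compound 2 showing a number 10.2 percentage points lower from compound 1 to compound 2 (beyond the scatter) and on compound 3 starting at -19.8%. The estimated value for compound 4 is therefore -30%, with an expected range from -45% to -15%.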

Compound 4, a percentage reported as activity, at one concentration (the size of the read-out at that concentration, not a potency): -19.8%
Compound 4: the middle estimate sits 10.2 percentage points below what was measured; low and high end bracket the measured number.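

On the core of compound 3, chloro in place of trifluoromethyl in this assay gives no change at the digits printed from compound 3 to compound 4 (within the scatter), and this step does not differ clearly from the one on the core of compound 1: the same change on two cores in this assay, a number 10.2 percentage points lower (beyond the scatter) from compound 1 to compound 2 and no change at the digits printed (within the scatter) from compound 3 to compound 4, 10.2 percentage points apart, within the scatter of two such steps

Methyl in place of hydrogen on the oxygen gives a number 15.3 percentage points higher from compound 2 to compound 4 (beyond the scatter), and this step likewise cannot be set apart from its earlier counterpart: the same change on two cores in this assay, a number 5.1 percentage points higher (within the scatter) from compound 1 to compound 3 and a number 15.3 percentage points higher (beyond the scatter) from compound 2 to compound 4, 10.2 percentage points apart, within the scatter of two such steps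

The two pairs are therefore compatible with the chloro change carrying across the two cores, but they do not show that it has the same size on both, nor that it is lost on the core of compound 3.

The compounds shown leave open how bromo, methyl or a nitrile would behave at the place of the trifluoromethyl group. They also leave open whether the change would carry to cores bearing an amine or a carboxylic acid in place of the hydroxy or methoxy group.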